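Clearance notes on the amine nitrogen substituent

A few compounds are considered here, and "the series" means these few. Any claim that something is new, unique, unknown or untested is made for them only; others in the source may bear on it.

- compound 1 `CC(C)(C)N1C[C@H](C(=O)Nc2ccc(Cl)cc2)[C@@H](c2ccc(/C=C/C(=O)Nc3ccccc3N)cc2)C1`: 60 mL/min/kg
- compound 2 `CC(C)(CO)N1C[C@H](C(=O)Nc2ccc(Cl)cc2)[C@@H](c2ccc(/C=C/C(=O)Nc3ccccc3N)cc2)C1`: 27 mL/min/kg

In an in vivo ADME assay on the whole organism (strain BALB/C) for pharmacokinetics, with Mus musculus as the target, read by LC-MS (a higher number here means faster removal of the compound, a lower number slower removal), compound 2 is the lower of the two measured compounds, at 27 mL/min/kg. The next compound is compound 3 `Nc1ccccc1NC(=O)/C=C/c1ccc([C@H]2CN(C3CCOCC3)C[C@@H]2C(=O)Nc2ccc(Cl)cc2)cc1`, with oxan-4-yl in place of 1-(hydroxymethyl)-1-methylethyl on an amine nitrogen in a ring. For the measured compounds named here, only one measured step bears on this change: a 2.2-fold lower number from compound 1 to compound 2 (0.35 log units; beyond the scatter). Going by the values given here, that modest step came from hydroxy in place of hydrogen on a saturated chain carbon, and no measured compound yet carries oxan-4-yl. The guide is therefore indirect, and the expectation in this assay is a small rise that may stay within the scatter. The expected change is a 1.3-fold higher number from compound 2 to compound 3 (0.11 log units; within the scatter). Compound 3 is estimated at 35 mL/min/kg, with an expected range of 15 mL/min/kg to 70 mL/min/kg.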

Compound 3, clearance: 39 mL/min/kg
The estimate for compound 3 lay 1.1-fold (0.05 log units) below the measured number, within the range that was stated.
By their numbers in this assay, from the lowest: compounds 2, 3 and 1 (each within the scatter of the next, the first and the last beyond it).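

In this assay, replacing the open-chain groups on the amine nitrogen with oxan-4-yl gives a 1.4-fold higher number from compound 2 to compound 3 (0.16 log units; within the scatter) and a 1.5-fold lower number from compound 1 to compound 3 (0.19 log units; within the scatter), so compound 3 cannot be told apart from either neighbour, although those two neighbours are separated by a 2.2-fold lower number from compound 1 to compound 2 (0.35 log units; beyond the scatter). At this position, therefore, a ring substituent with 0 hydrogen-bond donors is compatible with a number in the same band as compound 2, whose 1-(hydroxymethyl)-1-methylethyl group carries 1 hydrogen-bond donor. Nothing at hand explains why these numbers fall where they do.

From the compounds shown here alone, the role of the oxygen in oxan-4-yl remains open, and a cyclohexyl group on the same nitrogen would address it. Also open, going by these compounds, is whether a carboxylic acid or a longer hydroxyalkyl chain at this position would move the number beyond the scatter from compound 2.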